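The source may hold more compounds than are shown below. What is called first, only, known or untested is meant among the compounds shown, and "the series" means these compounds.

Measured so far in a functional assay on WI-38 VA13 cells (Homo sapiens) for cytotoxicity; on this read-out lower numbers stand for an effect already at smaller amounts and higher numbers for an effect only at larger amounts of compound:
compound 1 `CC(C)CC(=O)Nc1nc2ccc(NC(=O)c3c(Cl)cccc3Cl)cc2s1` gives 0.012 ug/mL
compound 2 `COCCOC(=O)Nc1nc2ccc(NC(=O)c3c(Cl)cccc3Cl)cc2s1` gives 0.011 ug/mL

Among the compounds with values here, only two compounds have numbers, and they sit side by side: the step of a 1.1-fold lower number from compound 1 to compound 2 (0.04 log units; within the scatter) is within the scatter, so compound 2 and compound 1 cannot be told apart on this read-out. Within the data shown here, both carry the same dichlorobenzamide and the same shared core; the one exchange made so far, isobutyl for 2-methoxyethoxy on the carbonyl carbon, left the number where it was.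

Compound 3 `O=C(Nc1nc2ccc(NC(=O)c3c(Cl)cccc3Cl)cc2s1)Oc1ccccc1` is not yet measured. Its change against compound 2 is phenyl in place of 2-methoxyethyl on an oxygen next to a carbonyl group. Among the measured compounds shown here, the sole step that bears on it is the one from compound 1 to compound 2, which was flat, and it is the same position that is varied again. Compound 3 is therefore expected to give a step of about a 1.1-fold higher number from compound 2 to compound 3 (0.04 log units; within the scatter), none beyond the scatter, because a 1.1-fold lower number from compound 1 to compound 2 (0.04 log units; within the scatter) showed no sensitivity at this site. The estimate for compound 3 in this assay is 0.012 ug/mL, with a range from 0.004 ug/mL to 0.04 ug/mL.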

Compound 3, half-maximal effective concentration: 1.1 ug/mL
Estimate against measurement, compound 3: 92-fold (1.96 log units) below, and the stated range ends below it.
By their numbers in this assay, from the lowest: compounds 2 and 1 (each within the scatter of the next); then compound 3.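

The position is not indifferent to change: in this assay the phenyl exchange moves the number far beyond the scatter (a 100-fold higher number from compound 2 to compound 3 (2.00 log units; beyond the scatter)), and the comparison with the isobutyl compound gives a step of similar size (a 92-fold higher number from compound 1 to compound 3 (1.96 log units; beyond the scatter)). The flat exchange between isobutyl and 2-methoxyethoxy therefore does not extend to phenoxy, and since compound 2 and compound 3 both carry an oxygen on the carbonyl carbon, that oxygen alone does not go with the higher number. No measurement available here explains the jump.

From the compounds shown here alone, whether the rise belongs to phenyl specifically or to any ring at this place remains open, and cyclohexyl or benzyl on the same oxygen would separate the two readings. Also open, going by these compounds, is how a substituted phenyl, such as 4-methoxyphenyl, would read.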